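This account rests on a few compounds, and the source may have more. Where it says the series, first, only, none or still open, it means among the compounds named here.

Measured so far in an in vitro ADME assay on microsomes from liver (Homo sapiens) for metabolic stability (a higher number here means that the compound lasts longer, a lower number that the compound disappears faster), for this series
- compound 1 `O=C1COCCN1c1ccc(C2CC(c3ccc([N+](=O)[O-])o3)=NO2)cn1` gives 1.52 h
- compound 2 `O=[N+]([O-])c1ccc(C2=NOC(c3ccc(N4CCCCC4)cc3)C2)o1` gives 0.47 h
- compound 3 `CN1CCN(c2ccc(C3CC(c4ccc([N+](=O)[O-])o4)=NO3)cc2F)C(=O)C1` gives 4.81 h

Compound 1 stands in the middle of the three, with compound 3 higher and compound 2 lower, both gaps beyond the scatter. Next is compound 4 `CN1CCN(c2ccc(C3CC(c4ccc([N+](=O)[O-])o4)=NO3)cn2)C(=O)C1` with the change 4-methyl-2-oxopiperazin-1-yl in place of 3-oxomorpholin-4-yl on an aromatic carbon in which 4-methyl-2-oxopiperazin-1-yl takes the place of 3-oxomorpholin-4-yl on an aromatic carbon next to the ring nitrogen. Among the compounds with values here, no direct step of this kind has been measured. The same group sits on a different aromatic ring in compound 3 at 4.81 h and this favours a small rise at most. The expected step is a 1.4-fold higher number from compound 1 to compound 4 (0.16 log units; within the scatter) which is upward but not beyond the scatter. For compound 4 the half-life is estimated at 2.2 h within an expected range of 0.9 h to 5 h in this assay once measured.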

Compound 4, half-life in the Homo sapiens assay: 4.24 h
Compound 4: the middle estimate sits 1.9-fold (0.28 log units) below what was measured; low and high end bracket the measured number.
By their numbers in the Homo sapiens assay, from the lowest: compound 2; then compound 1; then compounds 4 and 3 (each within the scatter of the next).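

On the aromatic carbon next to the ring nitrogen, 4-methyl-2-oxopiperazin-1-yl in place of 3-oxomorpholin-4-yl gives, in the Homo sapiens assay, a 2.8-fold higher number from compound 1 to compound 4 (0.45 log units; beyond the scatter), with compound 1 at 1.52 h and compound 4 at 4.24 h as the only direct reading of this change among the compounds shown. In a physicochemical assay for solubility, with a stated time of 18 h, at pH 7.4 (a higher number here means a more soluble compound, a lower number a less soluble compound), compound 1 gives 21.9 ug/mL and compound 4 gives 28.9 ug/mL and the same change gives a 1.3-fold higher number from compound 1 to compound 4 (0.12 log units; within the scatter), so the longer half-life comes with no separation in solubility. Nothing available explains the step.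

Open, from the compounds shown here alone, is whether an unsubstituted 2-oxopiperazin-1-yl, or an ethyl or acetyl group in place of the methyl, keeps this half-life. Also open, going by these compounds, is whether the change reads the same on the aromatic ring of compound 3.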